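Replacing a seven-membered ring with a smaller two-ring group

This account rests on a few compounds, and the source may have more. Where it says the series, first, only, none or still open, it means among the compounds named here.

Of the compounds shown here, three sharing one core have been measured in an assay on isolated protein for displacement of a labelled ligand from melanin-concentrating hormone receptor 1 (Homo sapiens); on this read-out lower numbers stand for stronger inhibition and higher numbers for weaker inhibition. Compound 1 `CC(=O)NC1CCN(c2ccc3cc(NC(=O)CCc4ccc(C(F)(F)F)cc4)ccc3n2)C1` gives 5 nM. Compound 2 `O=C(CCc1ccc(C(F)(F)F)cc1)Nc1ccc2nc(N3CC4CCC3CC4)ccc2c1` gives 3 nM. Compound 3 `O=C(CCc1ccc(C(F)(F)F)cc1)Nc1ccc2nc(N3CCCCCC3)ccc2c1` gives 36 nM, the highest of the three numbers, so the weakest binding here; its nearest neighbour is compound 1 at a 7.2-fold higher number from compound 1 to compound 3 (0.86 log units; beyond the scatter), and its furthest is compound 2 at a 12-fold higher number from compound 2 to compound 3 (1.08 log units; beyond the scatter). The gap between compound 1 and compound 2 is only a 1.7-fold lower number from compound 1 to compound 2 (0.22 log units; within the scatter).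

Compound 4 `O=C(CCc1ccc(C(F)(F)F)cc1)Nc1ccc2nc(N3CC4CCC3C4)ccc2c1` differs from compound 3 in one place: a group of 7 heavy atoms (6 carbon, 1 nitrogen; one five-membered non-aromatic ring of carbon only, one five-membered non-aromatic ring with 1 hetero atom) in place of a group of 7 heavy atoms (6 carbon, 1 nitrogen; one seven-membered non-aromatic ring with 1 hetero atom), on an aromatic carbon. The group that enters resembles the two-ring group of compound 2, only with one ring member fewer, while the group that leaves is the same seven-membered ring whose arrival in the step from compound 2 to compound 3 brought the large rise of a 12-fold higher number from compound 2 to compound 3 (1.08 log units; beyond the scatter). Closing the flexible ring back into a two-ring group is therefore expected to reverse most of that rise, giving a clearly lower number in this assay, though with no direct measurement of the smaller two-ring group some of the gain may be lost. The expected step is a 6.0-fold lower number from compound 3 to compound 4 (0.78 log units; beyond the scatter), and compound 4 is estimated at 6 nM, within a range of 2 nM to 20 nM.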

Compound 4, half-maximal inhibitory concentration: 1 nM
For compound 4 the middle estimate is 6.0-fold (0.78 log units) above the measured one; the measured number lies below the stated range.
By their numbers in this assay, from the lowest: compound 4; then compounds 2 and 1 (each within the scatter of the next); then compound 3.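

In this assay, this position, the aromatic carbon next to the ring nitrogen, turns out to respond to how a group's atoms are arranged and not only to how many there are: azepan-1-yl and the two-ring group that replaces it hold the same 7 heavy atoms (6 carbon, 1 nitrogen), yet the change gives a 36-fold lower number from compound 3 to compound 4 (1.56 log units; beyond the scatter). The smaller two-ring group also improves on both larger groups, with a 3.0-fold lower number from compound 2 to compound 4 (0.48 log units; beyond the scatter) and a 5.0-fold lower number from compound 1 to compound 4 (0.70 log units; beyond the scatter), which makes this the strongest binder of the four, and so more ring atoms are not needed for tight binding here. Nothing measured here explains why this arrangement is favoured.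

The compounds shown leave open whether two rings are needed at all, since an unbridged piperidin-1-yl or pyrrolidin-1-yl at this position would test that directly. They also leave open how much the two-ring group tolerates added atoms, for instance a hydroxyl or an amine on its all-carbon ring, and whether its gain would hold with a different chain in place of the trifluoromethyl-bearing side of the molecule.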